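This account rests on a few compounds, and the source may have more. Where it says the series, first, only, none or still open, it means among the compounds named here.

Measured in a physicochemical assay for solubility, at pH 7.4; a higher number here means a more soluble compound, a lower number a less soluble compound:
- compound 1 `C[C@H]1[C@H](N)CN1c1cc2c(cc1F)c(=O)c(C(=O)O)cn2C1CC1`: 9.9 ug/mL
- compound 2 `C[C@@H]1[C@@H](N(C)C)CN1c1c(F)cc2c(=O)c(C(=O)O)cn(C3CC3)c2c1F`: 97.1 ug/mL
- compound 3 `CC[C@H]1[C@@H](N)CN1c1cc2c(cc1F)c(=O)c(C(=O)O)cn2C1CC1`: 42.2 ug/mL

Compound 3 gives 42.2 ug/mL, the middle of the three numbers, below compound 2 and above compound 1. Compound 4 `C[C@@H]1[C@@H](N(C)C)CN1c1cc2c(cc1F)c(=O)c(C(=O)O)cn2C1CC1` differs from it in one place: a group of 8 heavy atoms (6 carbon, 2 nitrogen; one four-membered non-aromatic ring with 1 hetero atom) in place of a group of 7 heavy atoms (5 carbon, 2 nitrogen; one four-membered non-aromatic ring with 1 hetero atom), on an aromatic carbon. The group sits ortho to a fluoro group. Within the data shown here, one measured step bears on this, also a swap for a larger group: a 4.3-fold higher number from compound 1 to compound 3 (0.63 log units; beyond the scatter). Compound 2, with 97.1 ug/mL, carries the same entering group, but its core has one more fluoro group, so it offers only a rough guide. A modest rise in this assay is therefore expected, and the expected step is a 2.1-fold higher number from compound 3 to compound 4 (0.33 log units; beyond the scatter). The estimate for compound 4 is 90 ug/mL, with a range from 30 ug/mL to 250 ug/mL.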

Compound 4, solubility: 96.3 ug/mL
The estimate for compound 4 lay 1.1-fold (0.03 log units) below the measured number; low and high end bracket the measured number.
By their numbers in this assay, from the lowest: compound 1; then compound 3; then compounds 4 and 2 (each within the scatter of the next).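

In this assay, the group on the aromatic carbon ortho to a fluoro group again sets the size of the number, with the group of 8 heavy atoms and 0 hydrogen-bond donors giving the top result at this position (a 2.3-fold higher number from compound 3 to compound 4 (0.36 log units; beyond the scatter); a 9.7-fold higher number from compound 1 to compound 4 (0.99 log units; beyond the scatter)). The fluoro group that compound 2 adds to the core turns out to matter little, since hydrogen in its place stays within the scatter (a 1.0-fold lower number from compound 2 to compound 4 (0.00 log units; within the scatter)). No measurement shown explains these steps. Going by these compounds, whether a diethylamino group on the four-membered ring would give a higher number remains open.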